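A few compounds are considered here, and "the series" means these few. Any claim that something is new, unique, unknown or untested is made for them only; others in the source may bear on it.

Measured compounds:
- compound 1, `O=C(CSc1nnnn1-c1ccccc1)N/N=c1/scc(-c2ccc(Br)cc2)n1-c1ccccc1`, in a functional assay on C6 cells (Rattus norvegicus) for cytotoxicity, read by MTT assay, with a stated time of 24 h, tested at 12 ug/mL (on this read-out lower numbers stand for a stronger effect and higher numbers for a weaker effect at the one concentration tested), compound 1 gives 58.6%
- compound 2, `Cc1ccc(-c2cs/c(=N/NC(=O)CSc3nnnn3-c3ccccc3)n2-c2ccccc2)cc1`, in this assay compound 2 gives 55.1%

On the numbers shown compound 2 stands right beside compound 1: the only step seen so far, a number 3.5 percentage points lower from compound 1 to compound 2 (within the scatter), is too small to separate the two. Compound 3, `Cc1ccc(-c2cs/c(=N/NC(=O)CSc3nncn3C)n2-c2ccccc2)cc1`, differs from compound 2 in one place: 4-methyl-4H-1,2,4-triazol-3-yl in place of 1-phenyl-1H-tetrazol-5-yl on a sulfur. For the measured compounds named here, no measured step touches this part of the molecule; the one step known concerns a group on the aromatic ring at the other end of the shared core and changed nothing beyond the scatter. Going by the values given here, the numbers so far give no reason to expect a step beyond the scatter from this change either, so the estimated step is a number 1.9 percentage points higher from compound 2 to compound 3 (within the scatter), with a wide range to allow for an untested position. The estimated value for compound 3 in this assay is therefore 57%, expected between 42% and 72%.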

Compound 3, a percentage reported as activity, at one concentration (the size of the read-out at that concentration, not a potency): 72%
Compound 3: the middle estimate sits 15 percentage points below what was measured; the measured number falls inside the stated range.
By their numbers in this assay, from the lowest: compounds 2 and 1 (each within the scatter of the next); then compound 3.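

The group on the sulfur turns out to matter in this assay and the change to 4-methyl-4H-1,2,4-triazol-3-yl gives a number 16.9 percentage points higher from compound 2 to compound 3 (beyond the scatter) and so a weaker effect at the one concentration tested. For the compounds shown here, this is the first step that rises above the scatter, whereas the swap of bromo for methyl on the aromatic ring gave only a number 3.5 percentage points lower from compound 1 to compound 2 (within the scatter) and could not separate its two compounds. No measurement shown here explains the loss of effect.

The change alters the ring and removes the phenyl ring while adding a methyl, so these parts cannot be told apart from this one step. Placing 4-phenyl-4H-1,2,4-triazol-3-yl or 1-methyl-1H-tetrazol-5-yl on the same sulfur would show which part carries the difference.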